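Notes on an aryl swap at the sulfonyl sulfur

This account rests on a few compounds, and the source may have more. Where it says the series, first, only, none or still open, it means among the compounds named here.

In a functional assay (thoracic aorta) for inhibition, with Rattus norvegicus as the target (a lower number here means a stronger inhibitor, a higher number a weaker inhibitor), compound 1 (`O=C(O)c1cc(CCCNS(=O)(=O)c2ccccc2)c2cccccc1-2`) gives 4800 nM and compound 2 (`O=C(O)c1cc(CCCCCCNS(=O)(=O)c2ccccc2)c2cccccc1-2`) gives 140 nM on the same read-out, a lower number than that of compound 1. Compound 3 (`COc1ccc(S(=O)(=O)NCCCCc2cc(C(=O)O)c3ccc(C(C)C)ccc2-3)cc1`) reads 160 nM in this assay and so stands within the scatter of compound 2, while lying well beyond the scatter under compound 1.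

Compound 4 (`CC(C)c1ccc2c(CCCCNS(=O)(=O)c3cccc(C(F)(F)F)c3)cc(C(=O)O)c-2cc1`) has not yet been measured. It differs from compound 3 by 3-(trifluoromethyl)phenyl in place of 4-methoxyphenyl on a sulfonyl sulfur (in words, 3-(trifluoromethyl)phenyl in place of 4-methoxyphenyl on a sulfonyl sulfur). For the measured compounds named here, no measured pair isolates a change at this place, so the data offer no direct guide to its size or direction. The anchor for the expectation is therefore compound 3 at 160 nM with a wide range kept around it. In this assay the estimated 1.2-fold lower number from compound 3 to compound 4 (0.09 log units; within the scatter) is expected to stay within the scatter. For compound 4 the expected value is 130 nM (estimated range 40 nM to 420 nM).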

Compound 4, half-maximal inhibitory concentration: 1600 nM
Compound 4: the middle estimate sits 12-fold (1.09 log units) below what was measured, and the stated range ends below it.
By their numbers in this assay, from the lowest: compounds 2 and 3 (each within the scatter of the next); then compound 4; then compound 1.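

The sulfonyl sulfur now has its first measured single change: in this assay, 3-(trifluoromethyl)phenyl in place of 4-methoxyphenyl on a sulfonyl sulfur gives a 10-fold higher number from compound 3 to compound 4 (1.00 log units; beyond the scatter). The aryl group at this place therefore affects the read-out, and this swap moves it towards weaker inhibition with the rest of the molecule unchanged, which compound 1 and compound 2 could not show because neither forms a single-change pair with compound 3. No measured property bears on this step, so the data assign it no cause.

The swap replaces the methoxy group with trifluoromethyl and also changes the numbered ring position, so the compounds shown do not separate these two changes. As far as these compounds go, whether a nitrile or a methyl group in place of trifluoromethyl would read closer to compound 3 or to compound 4 remains open.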